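Methyl to Methoxy in a Weakly Active Series

The source may report more compounds than this note shows. Statements on the series, on what has been measured and on what is new or still open speak of the compounds shown alone.

Measured in a functional assay on HepG2 cells (Homo sapiens) for antiproliferative activity, read by MTT assay, with a stated time of 72 h; on this read-out lower numbers stand for stronger inhibition and higher numbers for weaker inhibition:
Compound 1 `COc1ccc(N2C(=O)COc3ccc(-c4cnc(Cl)c(NS(=O)(=O)c5ccc(F)cc5)c4)cc32)cc1` gives > 40000 nM, a limit of the assay.
Compound 2 `Cc1ccc(N2C(=O)COc3ccc(-c4cnc5ccccc5c4)cc32)cc1` gives > 40000 nM, a limit of the assay.
Compound 3 `Cc1ccc(N2C(=O)COc3ccc(-c4cnc(Cl)c(NS(=O)(=O)c5ccc(F)cc5)c4)cc32)cc1` gives 39600 nM.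

Compound 3 and compound 1 differ by methoxy in place of methyl on an aromatic carbon; the measured step is a number no lower from compound 3 to compound 1 (the limit leaves the size open), and its open size follows from the limit of > 40000 nM in this assay, at which 2 of the 3 values shown sit. Compound 4 `COc1ccc(N2C(=O)COc3ccc(-c4cnc5ccccc5c4)cc32)cc1` is not yet measured; it differs from compound 2 by methoxy in place of methyl on an aromatic carbon, the same change at the same place. The difference between the core of compound 2 and the core of compound 3 is not broken down here. Beside a number no lower from compound 3 to compound 1 (the limit leaves the size open), the expected step is a step that the limit leaves unreadable from compound 2 to compound 4. This expectation rests on the limit at which compound 2 sits, (the limit of > 40000 nM in this assay, at which 2 of the 3 values shown sit). Compound 4 is therefore estimated at 60000 nM, between 30000 nM and 150000 nM, most likely reported again only as a limit.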

Compound 4, half-maximal inhibitory concentration: > 40000 nM
Compound 4: no number, only a limit; the forecaster's own chance of this, stated with the estimate: 90%; the middle value is on the limit's open side.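

Compound 2 and compound 4 both give only a limit of the assay, not a number, so no new step can be read between them: the limit of > 40000 nM in this assay, at which 3 of the 4 values shown sit.

The compounds shown leave open how large the change from 4-methylphenyl to 4-methoxyphenyl is on either core.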